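This account rests on a few compounds, and the source may have more. Where it says the series, first, only, none or still open, it means among the compounds named here.

Measured in a functional assay on MCF7 cells (Homo sapiens) for cytotoxicity, read by MTT assay, with a stated time of 96 h; on this read-out lower numbers stand for stronger inhibition and higher numbers for weaker inhibition:
- compound 1 `COc1cc(C(=O)c2cn(-c3ccc(N)cc3)cc2-c2ccccc2)cc(OC)c1OC` gives 35 nM
- compound 2 `COc1cc(C(=O)c2cn(-c3ccccc3)cc2-c2ccc([N+](=O)[O-])cc2)cc(OC)c1OC` gives 590 nM
- compound 3 `COc1cc(C(=O)c2cn(-c3ccc(N)cc3)cc2-c2ccccc2Cl)cc(OC)c1OC` gives 83 nM

Compound 3 stands in the middle of the three numbers, above compound 1 and below compound 2. The next structure, compound 4 `COc1cc(C(=O)c2cn(-c3ccc(N)cc3)cc2-c2ccc([N+](=O)[O-])cc2)cc(OC)c1OC`, follows from compound 3 by 4-nitrophenyl in place of 2-chlorophenyl on an aromatic carbon, and the 4-aminophenyl group stays. Within the data shown here, the one measured step on the group that changes is a 2.4-fold higher number from compound 1 to compound 3 (0.38 log units; beyond the scatter), a modest step for chloro in place of hydrogen on an aromatic carbon. Among the measured compounds shown here, no measured step covers the 4-nitrophenyl group with the 4-aminophenyl group present. Compound 2 holds the 4-nitrophenyl group without the 4-aminophenyl group and gives 590 nM, so some upward pull is expected, but its size is not fixed by these data. In this assay a small upward step is therefore expected, possibly none beyond the scatter. The expected step is a 1.3-fold higher number from compound 3 to compound 4 (0.12 log units; within the scatter) and the uncertainty around it is wide. For compound 4 the estimated value is 110 nM, with an expected range of 35 nM to 350 nM.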

Compound 4, half-maximal inhibitory concentration: 260 nM
Beside the measured number, compound 4's estimate is 2.4-fold (0.37 log units) below it; the measured number falls inside the stated range.
By their numbers in this assay, from the lowest: compound 1; then compound 3; then compound 4; then compound 2.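

In this assay, with the 4-aminophenyl group held, 4-nitrophenyl at this position gives a higher number than 2-chlorophenyl (a 3.1-fold higher number from compound 3 to compound 4 (0.50 log units; beyond the scatter)) and a higher number than the plain phenyl of the core (a 7.4-fold higher number from compound 1 to compound 4 (0.87 log units; beyond the scatter)). The amino group still lowers the number with 4-nitrophenyl present (a 2.3-fold lower number from compound 2 to compound 4 (0.36 log units; beyond the scatter)), so the upward step from the nitro group and the downward step from the amino group both appear in this one pair of changes. Nothing measured here gives a reason for these steps.

Open, as far as these compounds go, is whether the higher number goes with the nitro group itself or with its place on the ring, as 2-chlorophenyl and 4-nitrophenyl differ in both; 4-chlorophenyl or 2-nitrophenyl at this position would separate the two. Also open, from the compounds shown here alone, is where a 4-methoxyphenyl or 4-carboxyphenyl group would fall here.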